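Metabolic stability of the peroxide series: amine substituent variants

This account rests on a few compounds, and the source may have more. Where it says the series, first, only, none or still open, it means among the compounds named here.

Measured so far in an ADME assay on microsomes from liver (Homo sapiens) for metabolic stability, read by LC-MS, tested at 1 uM; on this read-out lower numbers stand for slow clearance and higher numbers for fast clearance: compound 1 `CC(C)(O)CN1CCC(Oc2ccc([C@H]3CC[C@]4(CC3)OOC3(O4)C4CC5CC(C4)CC3C5)cc2)CC1` gives 18 mL.min-1.g-1. Compound 2 `c1cc([C@H]2CC[C@]3(CC2)OOC2(O3)C3CC4CC(C3)CC2C4)ccc1OCC1CCNCC1` gives < 7 mL.min-1.g-1, which is a limit of this assay and not a number. Compound 3 `c1cc([C@H]2CC[C@]3(CC2)OOC2(O3)C3CC4CC(C3)CC2C4)ccc1OCCCNC1CCOCC1` gives 10 mL.min-1.g-1.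

Compound 3 holds the lowest of the two numbers; its nearest neighbour is compound 1, with a 1.8-fold lower number from compound 1 to compound 3 (0.26 log units; within the scatter), and the remaining value, that of compound 2, is a limit (the limit of < 7 mL.min-1.g-1 in this assay, at which 1 of the 3 values shown sits).

The next step, to compound 4 `N[C@H]1CC[C@H](Oc2ccc([C@H]3CC[C@]4(CC3)OOC3(O4)C4CC5CC(C4)CC3C5)cc2)CC1`, is 4-aminocyclohexyl in place of 3-((oxan-4-yl)amino)propyl on an oxygen on an aromatic ring.

Going by the values given here, three measured steps bear on it. The change from the 1-(2-hydroxy-2-methylpropyl)piperidin-4-yl of compound 1 gave an at least 2.5-fold lower number from compound 1 to compound 2 (0.41 log units; beyond the scatter) and a 1.8-fold lower number from compound 1 to compound 3 (0.26 log units; within the scatter), and between the two smaller substituents there was an at least 1.4-fold higher number from compound 2 to compound 3 (0.15 log units; that floor lies within the scatter). Among the compounds with values here, compound 2, which carries (piperidin-4-yl)methyl, is the only member at the limit (the limit of < 7 mL.min-1.g-1 in this assay, at which 1 of the 3 values shown sits). Compound 4 likewise carries a ring bearing one hydrogen-bond donor without the oxan-4-yl group, so a downward step is expected, of the order of a 1.4-fold lower number from compound 3 to compound 4 (0.15 log units; within the scatter), possibly reaching the limit again.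

Compound 4 is therefore estimated at 7 mL.min-1.g-1 in this assay, within a range of 4 mL.min-1.g-1 to 14 mL.min-1.g-1.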

Compound 4, intrinsic clearance in microsomes: < 7 mL.min-1.g-1
Compound 4: no number, only a limit (the forecaster's own chance of this, stated with the estimate: 45%); the middle value lies on the limit itself.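

In this assay compound 4 gives < 7 mL.min-1.g-1, which is a limit of the assay and not a number, and a second substituent on the oxygen on the aromatic ring now ends at that limit: the limit of < 7 mL.min-1.g-1 in this assay, at which 2 of the 4 values shown sit.

Putting 4-aminocyclohexyl in place of 1-(2-hydroxy-2-methylpropyl)piperidin-4-yl gives an at least 2.5-fold lower number from compound 1 to compound 4 (0.41 log units; beyond the scatter), so a drop beyond the scatter from compound 1 no longer rests on the (piperidin-4-yl)methyl group of compound 2 alone. Putting 4-aminocyclohexyl in place of 3-((oxan-4-yl)amino)propyl gives an at least 1.4-fold lower number from compound 3 to compound 4 (0.15 log units; that floor lies within the scatter), so a real drop from compound 3 is not established, and the step from compound 2 to compound 4 cannot be read, since both ends are limits.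

Where compound 2 and compound 4 truly stand relative to each other remains open, as the limit hides any difference between them. Also open, on these data alone, is whether a methyl group on the amine of 4-aminocyclohexyl, or a carboxylic acid in place of that amine, would keep the read-out at the limit in this assay.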